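Swapping the Amide Side Group on a Shared Core

The compounds below may be only part of what the source reports. "The series", "measured", "known", "first", "only" and "open" are said of these compounds alone.

Two related compounds have been tested so far for their effect on lung-derived cancer cells. In a functional assay on A549 cells (Homo sapiens) for inhibition, read by MTT assay, with a stated time of 72 h (on this read-out lower numbers stand for stronger inhibition and higher numbers for weaker inhibition), compound 1 (`COc1ccccc1-c1csc2cnc(Nc3ccc(C(=O)NC4CCNCC4)c(C)c3)nc12`) gives 870 nM, while compound 2 (`COc1ccccc1-c1csc2cnc(Nc3ccc(C(=O)NCC4CCNCC4)c(F)c3)nc12`) gives 3410 nM. Compound 2 therefore has the higher number of the two, which means the weaker inhibition, and the gap lies beyond the usual scatter. These two compounds differ in more than one place, so their gap cannot be tied to any single structural feature.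

Compound 3 (`COc1ccccc1-c1csc2cnc(Nc3ccc(C(=O)NC4CCOCC4)c(F)c3)nc12`) starts from compound 2 and places oxan-4-yl in place of (piperidin-4-yl)methyl on an amide-type nitrogen. Going by the values given here, no measured pair shows this kind of swap, so the data offer no direct guide to its size or direction. The expectation is therefore cautious, with no change beyond the scatter in this assay, and the estimated step of a 1.2-fold higher number from compound 2 to compound 3 (0.07 log units; within the scatter) reflects that. For compound 3, the expected value is 4000 nM, with an estimated range from 1000 nM to 15000 nM.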

Compound 3, half-maximal inhibitory concentration: 5710 nM
For compound 3 the middle estimate is 1.4-fold (0.15 log units) below the measured one; measured number inside the range.
By their numbers in this assay, from the lowest: compound 1; then compounds 2 and 3 (each within the scatter of the next).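

In this assay, going by these compounds alone, putting oxan-4-yl in place of (piperidin-4-yl)methyl on the amide-type nitrogen gives a 1.7-fold higher number from compound 2 to compound 3 (0.22 log units; within the scatter), the first step in this set where only this one place differs. The group that leaves holds a nitrogen and a hydrogen-bond donor, while the group that enters holds an oxygen and has no hydrogen-bond donor, yet on this read-out compound 2 and compound 3 cannot be told apart. No measurement shown here accounts for this outcome.

As far as these compounds go, compound 1 differs from compound 3 in more than one place, so it remains open whether this swap would give a similar result with the methyl group of compound 1 in place of the fluorine shared by compound 2 and compound 3. From the compounds shown here alone, it is also open how this assay would respond to other groups on the same amide-type nitrogen, such as a simple open-chain amine, a carboxylic acid or a longer chain ending in a piperidine ring.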